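Swapping Propyl for Cyclobutyl on an Aromatic Oxygen

A few compounds are considered here, and "the series" means these few. Any claim that something is new, unique, unknown or untested is made for them only; others in the source may bear on it.

Going by the values given here, compound 3 `CCCOc1cc([C@](O)(CCN(C)C)[C@@H](c2cc3cc(Br)ccc3nc2OC)c2ccnc(OC)c2OC)cc(OC)n1` gives 8.2 uL/min in an ADME assay on microsomes from liver (Homo sapiens) for metabolic stability (on this read-out lower numbers stand for slow clearance and higher numbers for fast clearance), the highest of the three numbers measured so far. Compound 2 `COc1cc([C@](O)(CCN(C)C)[C@@H](c2cc3cc(Br)ccc3nc2OC)c2ccnc(OC)c2OC)cc(OC(C)C)n1` gives 6.4 uL/min, and compound 1 `CCOc1cc([C@](O)(CCN(C)C)[C@@H](c2cc3cc(Br)ccc3nc2OC)c2ccnc(OC)c2OC)cc(OC)n1` gives 3.8 uL/min. The step of a 1.3-fold higher number from compound 2 to compound 3 (0.11 log units; within the scatter) lies within the scatter, a 1.7-fold higher number from compound 1 to compound 2 (0.23 log units; within the scatter) also lies within the scatter, whereas a 2.2-fold higher number from compound 1 to compound 3 (0.33 log units; beyond the scatter) is modest. Compound 4 `COc1cc([C@](O)(CCN(C)C)[C@@H](c2cc3cc(Br)ccc3nc2OC)c2ccnc(OC)c2OC)cc(OC2CCC2)n1` carries the change (cyclobutyl in place of propyl on an oxygen on an aromatic ring). All measured steps that altered the group on an oxygen on an aromatic ring were small or modest, so compound 4 is expected to show no more than a slight rise, a 1.2-fold higher number from compound 3 to compound 4 (0.06 log units; within the scatter), in this assay. For compound 4 the estimated value is 9.5 uL/min, with a range from 5 uL/min to 18 uL/min.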

Compound 4, intrinsic clearance in a liver preparation (reported as CLH), per the amount of preparation that the assay uses: 2.5 uL/min
The estimate for compound 4 lay 3.8-fold (0.58 log units) above the measured number, outside the stated range (below it).
By their numbers in this assay, from the lowest: compounds 4, 1, 2 and 3 (each within the scatter of the next, the first and the last beyond it).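

In this assay, cyclobutyl on this oxygen gives a lower number than the open-chain groups propyl and isopropyl, with a 3.3-fold lower number from compound 3 to compound 4 (0.52 log units; beyond the scatter) and a 2.6-fold lower number from compound 2 to compound 4 (0.41 log units; beyond the scatter) both beyond the scatter. Against ethyl, however, a 1.5-fold lower number from compound 1 to compound 4 (0.18 log units; within the scatter) stays within the scatter, so those two groups cannot be ordered. Cyclobutyl has the most heavy atoms of these groups, yet its compound does not give the highest number, so group size alone does not set the number here. As far as these compounds go, whether the ring itself matters stays open: cyclopropyl, cyclopentyl or a butyl chain on this oxygen would test that. No evidence on the cause of the drop is available.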